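This account rests on a few compounds, and the source may have more. Where it says the series, first, only, none or still open, it means among the compounds named here.

Measured so far:
- compound 1 `N=C(N)NCCC[C@@H](NC(=O)c1cnc2ccccc2c1)C(=O)NCc1ccc(C(F)(F)F)cc1`: 96 nM
- compound 2 `N=C(N)NCCC[C@@H](NC(=O)c1cc2cc(F)ccc2[nH]1)C(=O)NCc1ccc(C(F)(F)F)cc1`: 25 nM

In a functional assay on HEK293 cells for antagonist activity at melanin-concentrating hormone receptor 1 (Homo sapiens) (on this read-out higher numbers stand for weaker inhibition and lower numbers for stronger inhibition), compound 2 holds the lowest of the two numbers, with compound 1 the nearest at a 3.8-fold lower number from compound 1 to compound 2 (0.58 log units; beyond the scatter) above it in the reverse sense. Compound 3 `N=C(N)NCCC[C@@H](NC(=O)c1ccc(F)c2ccccc12)C(=O)NCc1ccc(C(F)(F)F)cc1` differs from compound 2 by 4-fluoronaphthalen-1-yl in place of 5-fluoro-1H-indol-2-yl on a carbonyl carbon. For the measured compounds named here, the only step that bears on this is the one from compound 1 to compound 2, a 3.8-fold lower number from compound 1 to compound 2 (0.58 log units; beyond the scatter), which also exchanged the bicyclic group on the carbonyl carbon. For the present exchange a step back toward the number of compound 1 is expected, a 3.2-fold higher number from compound 2 to compound 3 (0.51 log units; beyond the scatter). Compound 3 is therefore estimated at 80 nM, within 25 nM to 260 nM.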

Compound 3, half-maximal inhibitory concentration: 311 nM
Compound 3: the middle estimate sits 3.9-fold (0.59 log units) below what was measured; measured number outside the range, above it.
By their numbers in this assay, from the lowest: compound 2; then compound 1; then compound 3.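

On the carbonyl carbon, the choice of bicyclic group carries large consequences in this assay: 4-fluoronaphthalen-1-yl in place of 5-fluoro-1H-indol-2-yl gives a 12-fold higher number from compound 2 to compound 3 (1.09 log units; beyond the scatter), and in place of quinolin-3-yl it gives a 3.2-fold higher number from compound 1 to compound 3 (0.51 log units; beyond the scatter). The first exchange removes the counted hydrogen-bond donor and changes the ring together, so these compounds cannot separate the two. No measurement bears on the cause of either step. Open, from the compounds shown here alone, is whether 5-fluoro-1-methylindol-2-yl, with a methyl group on the ring nitrogen, stays near compound 2 or moves toward compound 3.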